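Swapping piperidine amide for furanylmethyl amide on a sulfonamide core

The source may report more compounds than this note shows. Statements on the series, on what has been measured and on what is new or still open speak of the compounds shown alone.

Measured so far:
- compound 1, `CC1=C(c2ccc3ccccc3c2)S(=O)(=O)N(Cc2ccc(C(=O)N3CCCCC3)cc2)C1=O`: 47900 nM
- compound 2, `O=C(NCc1ccco1)c1ccc(CN2C(=O)c3ccccc3S2(=O)=O)cc1`: limit of > 100000 nM
- compound 3, `O=C(c1ccc(CN2Cc3ccccc3S2(=O)=O)cc1)N1CCCCC1`: limit of > 100000 nM

All three were tested in an ADME assay on RAW264.7 cells (Mus musculus) for cytotoxicity, read by WST assay; on this read-out lower numbers stand for higher toxicity in this test and higher numbers for lower toxicity in this test. Compound 1 gives 47900 nM there. For compound 2 the read-out is not a number but a limit, > 100000 nM. For compound 3 the read-out is likewise only a limit, > 100000 nM. So compound 3 stands at the limit of > 100000 nM in this assay, at which 2 of the 3 values shown sit, the top of what this assay can report, meaning no toxicity was seen within the tested range.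

Compound 4, `O=C(NCc1ccco1)c1ccc(CN2Cc3ccccc3S2(=O)=O)cc1`, is not yet measured. It differs from compound 3 in one place: ((furan-2-yl)methyl)amino in place of piperidin-1-yl on a carbonyl carbon. The same ((furan-2-yl)methyl)carbamoyl group already sits on compound 2, which also sat at the limit in this assay. The step from compound 3 to compound 4 is therefore expected to show no change beyond the scatter, a step that the limit leaves unreadable from compound 3 to compound 4. Compound 4 is expected to give about 150000 nM, within a range from 60000 nM to 400000 nM, and most likely the assay will again report only a limit.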

Compound 4, concentration lethal to 50% of the cells: > 100000 nM
Compound 4 ended at the assay's limit; the forecaster's own chance of this, stated with the estimate: 80%; the middle value does not contradict the limit.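

Within the data shown here, compound 3 and compound 4 both sit at a limit of this assay, so no step between them can be read. The compounds shown leave open whether ((furan-2-yl)methyl)amino in place of piperidin-1-yl on a carbonyl carbon changes toxicity in this test at all.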